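Swapping the Pyridine on Compound 2 for an Imidazole

The source may report more compounds than this note shows. Statements on the series, on what has been measured and on what is new or still open speak of the compounds shown alone.

Compound 1 `CNC(=O)[C@@H]1CCCN1S(=O)(=O)c1ccc(Cl)c(COc2cccc3c(-c4ccncc4)cc(C)nc23)c1Cl`: 550 mL/min/kg
Compound 2 `CNC(=O)[C@@H]1CCCN1S(=O)(=O)c1ccc(Cl)c(COc2cccc3c(-c4ccncc4)cc(C(C)C)nc23)c1Cl`: 633 mL/min/kg

In an ADME assay on microsomes (Mus musculus) for metabolic stability (on this read-out lower numbers stand for slow clearance and higher numbers for fast clearance), the two measured numbers cannot be told apart: the isopropyl in place of methyl on an aromatic carbon gives a 1.2-fold higher number from compound 1 to compound 2 (0.06 log units; within the scatter). Within the data shown here, compound 2 thus stands level with its only measured neighbour. The next structure, compound 3 `CNC(=O)[C@@H]1CCCN1S(=O)(=O)c1ccc(Cl)c(COc2cccc3c(-c4cncn4C)cc(C(C)C)nc23)c1Cl`, keeps the isopropyl group and alters another place: 1-methyl-1H-imidazol-5-yl in place of pyridin-4-yl on an aromatic carbon. Among the measured compounds shown here, no measured step involves this exchange, and the single step available lies at a different place, so it offers only weak guidance. The expectation therefore starts from compound 2 at 633 mL/min/kg, and no shift beyond the scatter is expected in this assay, though the uncertainty is wide. The expected step is a 1.3-fold lower number from compound 2 to compound 3 (0.10 log units; within the scatter). For compound 3 the estimated clearance is 500 mL/min/kg, with an expected range of 220 mL/min/kg to 800 mL/min/kg.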

Compound 3, clearance: 100 mL/min/kg
Compound 3: middle estimate off by 5.0-fold (0.70 log units), on the high side, and the stated range ends above it.
By their numbers in this assay, from the lowest: compound 3; then compounds 1 and 2 (each within the scatter of the next).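

In this assay the place opposite the ring nitrogen turns out to matter: 1-methyl-1H-imidazol-5-yl in place of pyridin-4-yl gives a 6.3-fold lower number from compound 2 to compound 3 (0.80 log units; beyond the scatter) and so moves the number beyond the scatter, which the exchange of methyl for isopropyl on the same core did not do. Compound 3 is therefore the only compound shown that stands apart, while compounds 1 and 2 remain level with each other. Nothing shown here explains this change.

From the compounds shown here alone, the exchange appears only with the isopropyl group in place, so it remains open whether it would carry over to the methyl analogue of the core. Also open, going by these compounds, is whether the lower number needs the imidazole's methyl group, which a plain imidazol-5-yl or a pyrazole at this place would test.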